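This account rests on a few compounds, and the source may have more. Where it says the series, first, only, none or still open, it means among the compounds named here.

Measured compounds:
compound 1 `CCCCCCCCCCCCCCNC(=O)[C@@H](N)[C@@H](C)O`, 14600 nM
compound 2 `CCCCCCCCCCCCCCCCCCNC(=O)[C@@H](N)[C@@H](C)O`, 21300 nM
compound 3 `C/C=C/C=C/C(=O)N[C@H](C(=O)NCCCCCCCC)[C@@H](C)O`, 58200 nM

All three were tested in a functional assay on A-431 cells (Homo sapiens) for cytotoxicity, read by MTT assay, with a stated time of 48 h; a higher number here means a weaker inhibitor, a lower number a stronger inhibitor. Compound 1 gives the lowest of the three numbers. Compound 2 stands nearest: a 1.5-fold higher number from compound 1 to compound 2 (0.16 log units; within the scatter) lies within the scatter, so the two cannot be ordered. Compound 3 stands furthest, with a gap from compound 1 that is beyond the scatter; it differs from compound 1 in more than one place, so only its value is compared, not a single step.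

Compound 4 `CCCCCCCCCCCCCCNC(=O)[C@@H](NS(=O)(=O)c1cccs1)[C@@H](C)O` has not yet been measured. It differs from compound 1 by (thiophen-2-yl)sulfonyl in place of hydrogen on an amine nitrogen. Among the measured compounds shown here, no measured single step touches the amine nitrogen; the only one, a 1.5-fold higher number from compound 1 to compound 2 (0.16 log units; within the scatter), changes the chain and moves nothing beyond the scatter. Compound 3, in which the amine nitrogen is substituted and the chain is shorter, gives a higher number than compound 1, but this mixes two changes. Compound 4 is therefore expected to show a 1.7-fold higher number from compound 1 to compound 4 (0.23 log units; within the scatter), a modest rise. The estimate for compound 4 is 25000 nM, ranging from 8000 nM to 80000 nM.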

Compound 4, half-maximal inhibitory concentration: 22000 nM
Compound 4: middle estimate off by 1.1-fold (0.06 log units), on the high side; the measured number falls inside the stated range.
By their numbers in this assay, from the lowest: compounds 1, 2 and 4 (each within the scatter of the next); then compound 3.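

The amine nitrogen of compound 1 now has a measured single step of its own: in this assay, (thiophen-2-yl)sulfonyl in place of hydrogen on this nitrogen gives a 1.5-fold higher number from compound 1 to compound 4 (0.18 log units; within the scatter). On this core and with this chain, the nitrogen therefore carries a group of 8 heavy atoms, including a five-membered aromatic ring, and compound 1 and compound 4 cannot be ordered. No measurement is available that would explain this outcome. Going by these compounds, it remains open whether the sulfonyl link or the thiophene ring matters more, which an acetyl or a benzenesulfonyl group on the same nitrogen could help to separate. On these data alone, it also remains open whether the result would hold with a longer chain on the amide nitrogen.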